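Swapping a Sulfur Ring for an Oxygen Ring at the Chain End

This account rests on a few compounds, and the source may have more. Where it says the series, first, only, none or still open, it means among the compounds named here.

Measured so far:
Compound 1, `c1ccc2c(c1)CN[C@@H](CN(CCCCN(Cc1ccncc1)Cc1ccncc1)[C@H]1CCCc3cccnc31)C2`, in a functional assay on cells for agonist activity at C-X-C chemokine receptor type 4 (Homo sapiens), read by fluorescence and calcium flux, with a stated time of 90 s; a lower number here means that less compound is needed, a higher number that more compound is needed for the effect: > 30000 nM
Compound 2, `c1ccc2c(c1)CN[C@@H](CN(CCCCNCC1CCSCC1)[C@H]1CCCc3cccnc31)C2`, in this assay: > 30000 nM
Compound 3, `c1ccc(CNCc2ccc(CN(C[C@H]3Cc4ccccc4CN3)[C@H]3CCCc4cccnc43)cc2)nc1`, in this assay: > 30000 nM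

Each of these three values is a limit of the assay rather than a measured number. Compound 2 therefore has no number of its own; it stands at the limit of > 30000 nM in this assay, at which 3 of the 3 values shown sit, and the two other values shown stand there as well. Going by the values given here, no step between two measured compounds that differ in a single place is available, so nothing here shows how a single change moves the read-out.

Compound 4, `C(=C/CN(C[C@H]1Cc2ccccc2CN1)[C@H]1CCCc2cccnc21)\CNCC1CCOCC1`, is the next compound. Compared with compound 2 it carries a group of 11 heavy atoms (9 carbon, 1 nitrogen, 1 oxygen; one six-membered non-aromatic ring with 1 hetero atom) in place of a group of 11 heavy atoms (9 carbon, 1 nitrogen, 1 sulfur; one six-membered non-aromatic ring with 1 hetero atom), on a saturated chain carbon bound to an amine nitrogen.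

Because compound 2 sits at the limit of > 30000 nM in this assay, at which 3 of the 3 values shown sit, together with every other value shown, the step is expected to be none beyond the scatter, and the estimate for compound 4 is a number no higher from compound 2 to compound 4 (the limit leaves the size open). Compound 4 is expected at 30000 nM, within a range from 10000 nM to 100000 nM, most likely reported again as a limit.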

Compound 4, half-maximal effective concentration: > 30000 nM
Compound 4 was reported as a limit; the forecaster's own chance of this, stated with the estimate: 75%; the middle value lies on the limit itself.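

Compound 2 and compound 4 both end at a limit of the assay rather than at a measured number, so no step between them can be read: the limit of > 30000 nM in this assay, at which 4 of the 4 values shown sit.

The compounds shown leave open whether the oxygen ring in place of the sulfur ring changes how much compound is needed in this assay.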